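A few compounds are considered here, and "the series" means these few. Any claim that something is new, unique, unknown or untested is made for them only; others in the source may bear on it.

Measured so far in a functional assay on DLD-1 cells (Homo sapiens) for cytotoxicity; on this read-out higher numbers stand for weaker inhibition and lower numbers for stronger inhibition:
Compound 1, `N#C/N=C1\N(CCCCCCOc2ccc(Cl)cc2)C(=O)CN1c1ccncc1`, gives 3440 nM.
Compound 2, `N#C/N=C1\N(CCCCCCCOc2ccc(Cl)cc2)C(=O)CN1c1ccncc1`, gives 3340 nM.
Compound 3, `CCC1C(=O)N(CCCCCCOc2ccc(Cl)cc2)/C(=N\C#N)N1c1ccncc1`, gives 3560 nM.

All three numbers lie within the scatter of one another. From compound 1 to compound 3 the step was a 1.0-fold higher number from compound 1 to compound 3 (0.01 log units; within the scatter); the two cores differ by ethyl in place of hydrogen on a saturated ring carbon.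

Compound 4, `CCC1C(=O)N(CCCCCCCOc2ccc(Cl)cc2)/C(=N\C#N)N1c1ccncc1`, is not yet measured. It differs from compound 3 by (4-chlorophenoxy)methyl in place of 4-chlorophenoxy on a saturated chain carbon, six bonds along the chain from an amide-type nitrogen in a ring. The same change has already been made once on the other core, from compound 1 to compound 2: (4-chlorophenoxy)methyl in place of 4-chlorophenoxy on a saturated chain carbon, six bonds along the chain from an amide-type nitrogen in a ring. The place of the change is the same in both pairs, word for word. That earlier step gave a 1.0-fold lower number from compound 1 to compound 2 (0.01 log units; within the scatter).

For compound 4 the step of a 1.0-fold lower number from compound 3 to compound 4 (0.01 log units; within the scatter) in this assay is expected to be about as flat as the earlier one. This rests on one precedent only, because the same change gave a 1.0-fold lower number from compound 1 to compound 2 (0.01 log units; within the scatter) on a core that differs from that of compound 3 merely by the ethyl group. Compound 4 is therefore estimated at 3500 nM in this assay, with a range from 2000 nM to 6500 nM.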

Compound 4, half-maximal inhibitory concentration: 3530 nM
Beside the measured number, compound 4's estimate is 1.0-fold (0.00 log units) below it, within the range that was stated.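

In this assay, (4-chlorophenoxy)methyl in place of 4-chlorophenoxy on the ethyl-bearing core gives a 1.0-fold lower number from compound 3 to compound 4 (0.00 log units; within the scatter), and this step carries over from the core of compound 1 without a detectable difference: the same change on two cores in this assay, a 1.0-fold lower number (0.01 log units; within the scatter) from compound 1 to compound 2 and a 1.0-fold lower number (0.00 log units; within the scatter) from compound 3 to compound 4, 1.0-fold (0.01 log units) apart, within the scatter of two such steps

The ethyl change, read on the longer-chain pair, gives a 1.1-fold higher number from compound 2 to compound 4 (0.02 log units; within the scatter), and it too matches its earlier step: the same change on two cores in this assay, a 1.0-fold higher number (0.01 log units; within the scatter) from compound 1 to compound 3 and a 1.1-fold higher number (0.02 log units; within the scatter) from compound 2 to compound 4, 1.0-fold (0.01 log units) apart, within the scatter of two such steps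

Going by these compounds alone, this agreement is between flat steps on only two cores, so it shows that neither change moves the number on these cores in this assay, but it does not test whether a change that does move the number would carry over in the same way.

The compounds shown leave open whether a much longer chain or a shorter chain on the amide-type nitrogen would stay equally flat, and whether an amine or a carboxylic acid in place of 4-chlorophenoxy would shift the number. They also leave open whether a benzyl or isopropyl group in place of ethyl on the saturated ring carbon would do so.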